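Trimming the amine on the shared core of compound 1

The compounds below may be only part of what the source reports. "The series", "measured", "known", "first", "only" and "open" are said of these compounds alone.

Of the compounds shown here, two from this series have so far been measured in an assay on Sf9 cells for inhibition of activin receptor type-1 (Homo sapiens), read by HTRF, with a stated time of 3 h, in the presence of a further agent that is not named here; on this read-out lower numbers stand for stronger inhibition and higher numbers for weaker inhibition. Compound 1 `C[C@@H]1CN(c2ccc(-c3n[nH]c4cnc(N5[C@H](C)COC[C@@H]5C)nc34)cn2)CCN1` gives 23 nM in this assay, the higher of the two numbers. Compound 2 `CCOC(=O)N1C[C@@H](C)N(c2ncc3[nH]nc(-c4ccc(N5CCN[C@H](C)C5)nc4)c3n2)[C@@H](C)C1`, which carries a different amine on the shared core, gives 4.9 nM in this assay, a lower number whose gap from compound 1 lies beyond the usual scatter. Compound 3 `C[C@@H]1CN(c2ccc(-c3n[nH]c4cnc(N5CCCCC5)nc34)cn2)CCN1` has not yet been measured. It differs from compound 1 in one place: piperidin-1-yl in place of 3,5-dimethylmorpholin-4-yl on an aromatic carbon. Going by the values given here, no measured pair shows this change on its own, so its effect can only be anticipated. The change is expected to bring a modest move towards weaker inhibition, with the step of a 1.7-fold higher number from compound 1 to compound 3 (0.24 log units; within the scatter) likely to sit near the edge of the scatter. Compound 3 is therefore expected to give about 40 nM in this assay, within a range of 12 nM to 130 nM.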

Compound 3, half-maximal inhibitory concentration: 40 nM
Estimate against measurement, compound 3: no gap at the digits printed; low and high end bracket the measured number.
By their numbers in this assay, from the lowest: compound 2; then compounds 1 and 3 (each within the scatter of the next).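

In this assay, going by these compounds alone, replacing 3,5-dimethylmorpholin-4-yl with piperidin-1-yl on the shared core gives a 1.7-fold higher number from compound 1 to compound 3 (0.24 log units; within the scatter) and provides the first reading of a change at this position alone. On this read-out, the ring oxygen and the two methyl groups can therefore be removed together, along with both defined stereocentres, without a step beyond the scatter. No measurement shown bears on why this step is the size it is.

Within the data shown here, the single step cannot separate the contribution of the ring oxygen from that of the two methyl groups, and unsubstituted morpholin-4-yl or 3,5-dimethylpiperidin-1-yl at this position would be needed to do so. From the compounds shown here alone, it also remains open whether an open-chain amine such as dimethylamino would stay within the scatter of compound 1.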